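This account rests on a few compounds, and the source may have more. Where it says the series, first, only, none or still open, it means among the compounds named here.

The measured compounds and their values:

Compound 1 `CCC(C)(C)Cc1c[nH]c(CCc2ccc(-c3cccc(C)n3)cc2)n1` gives 106 nM in a functional assay on HEK293 cells for agonist activity at Bombesin receptor subtype-3 (Mus musculus), read by luminescence and calcium flux, with a stated time of 10 min; a lower number here means that less compound is needed, a higher number that more compound is needed for the effect.
Compound 2 `CCC(C)(C)Cc1c[nH]c(CCc2ccc(-n3ncnn3)cc2)n1` gives 99 nM in this assay.
Compound 3 `CCC(C)(C)Cc1c[nH]c(CCc2ccc(-c3cnccn3)cc2)n1` gives 107 nM in this assay.

The three compounds share one core and differ only in the aromatic group attached to an aromatic carbon of the six-membered carbon ring. Compound 3 sits alongside the other two: the steps of a 1.0-fold higher number from compound 1 to compound 3 (0.00 log units; within the scatter) and a 1.1-fold higher number from compound 2 to compound 3 (0.03 log units; within the scatter) both lie within the scatter, and the step of a 1.1-fold lower number from compound 1 to compound 2 (0.03 log units; within the scatter) does the same, so across these three compounds the heteroaryl group was exchanged three ways without a change that can be told from noise.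

Compound 4 `CCC(C)(C)Cc1c[nH]c(CCc2ccc(-c3cccc(C#N)n3)cc2)n1` continues this series with the change (6-cyanopyridin-2-yl in place of pyrazin-2-yl on an aromatic carbon). The three measured steps are the ones that bear on it: each swapped one small aromatic group for another at the same place, and each stayed within the scatter. A nitrile is new to the set, so the evidence is indirect, but nothing measured points to a shift in either direction. Compound 4 is therefore expected to give 105 nM in this assay, with a range from 50 nM to 220 nM. That estimate means a step of a 1.0-fold lower number from compound 3 to compound 4 (0.01 log units; within the scatter), which is expected to remain within the scatter.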

Compound 4, half-maximal effective concentration: 115 nM
Estimate against measurement, compound 4: 1.1-fold (0.04 log units) below, within the range that was stated.
By their numbers in this assay, from the lowest: compounds 2, 1, 3 and 4 (each within the scatter of the next).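

In this assay, replacing pyrazin-2-yl with the larger 6-cyanopyridin-2-yl, on an aromatic carbon para to a large group, gave a 1.1-fold higher number from compound 3 to compound 4 (0.03 log units; within the scatter) and so added no change that can be told from noise, and replacing 2H-tetrazol-2-yl with the same group gave a 1.2-fold higher number from compound 2 to compound 4 (0.07 log units; within the scatter) with the same outcome. The closest comparison in the set is also the one that isolates the nitrile, since cyano in place of methyl on the otherwise unchanged pyridinyl group gave a 1.1-fold higher number from compound 1 to compound 4 (0.04 log units; within the scatter) and left the two compounds indistinguishable in this assay. This position therefore accepts a group with a triple bond outside aromatic rings, as well as one with more heavy atoms than pyrazin-2-yl, without a measurable shift, but no measurement shown here offers an explanation for that flat response.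

All four compounds carry an aromatic ring at this place, so the compounds shown leave open how a carboxylic acid, an amine or a longer alkyl chain there would behave. They also leave open whether the 2,2-dimethylbutyl chain of the shared core is as open to change as this position has been.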